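Oxamide to aryloxyacetamide series: methyl on the chain carbon

The source may report more compounds than this note shows. Statements on the series, on what has been measured and on what is new or still open speak of the compounds shown alone.

Measured so far:
compound 1, `O=C(O)COc1ccc(NC(=O)C(=O)Nc2ccccc2)cc1F`, 9.78%
compound 2, `O=C(O)COc1ccc(NC(=O)COc2ccccc2)cc1F`, 29.8%

Of the two compounds with numbers, compound 2 stands highest in a functional assay on CHO cells for agonist activity at Free fatty acid receptor 1 (Homo sapiens), read by FLIPR, tested at 100 nM; a lower number here means a weaker effect, a higher number a stronger effect of the compound at the concentration tested; its nearest neighbour, compound 1, lies lower by a gap beyond the usual scatter. Within the data shown here, no single-point step between the two measured compounds is defined, so only their two values can be compared.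

Compound 3, `CC(Oc1ccccc1)C(=O)Nc1ccc(OCC(=O)O)c(F)c1`, has not been measured. It differs from compound 2 by methyl in place of hydrogen on a saturated chain carbon bound to a carbonyl carbon and an oxygen on an aromatic ring. Among the measured compounds shown here, no measured pair shows what this change does, and the shared core is otherwise unaltered.

With nothing in the data to point either way, a step from compound 2 to compound 3 of a number 3.2 percentage points higher from compound 2 to compound 3 (within the scatter) in this assay is expected, that is, no change beyond the scatter. Going by these compounds, for compound 3 the estimate is 33%, with a range from 12% to 58%, the width reflecting that the change is untested.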

Compound 3, a percentage reported as activity, at one concentration (the size of the read-out at that concentration, not a potency): 35.7%
Compound 3: the middle estimate sits 2.7 percentage points below what was measured, and the stated range covers the measured number.
By their numbers in this assay, from the lowest: compound 1; then compounds 2 and 3 (each within the scatter of the next).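

In this assay, among these compounds, methyl in place of hydrogen on a saturated chain carbon bound to a carbonyl carbon and an oxygen on an aromatic ring gives a number 5.9 percentage points higher from compound 2 to compound 3 (within the scatter) as the first single-place step. This position therefore accepts the added methyl without a change beyond the scatter, which compounds 1 and 2 could not show, as they differ in more than one place. Nothing on hand accounts for this outcome.

Still open, going by these compounds, is whether the same chain carbon also accepts an ethyl group, a second methyl or a hydroxyl group. A read-out at one concentration also leaves open whether compound 2 and compound 3 would give matching effects at other concentrations.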